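Benzyl for 4-fluorophenyl on the fused core: compound 4

The compounds below may be only part of what the source reports. "The series", "measured", "known", "first", "only" and "open" are said of these compounds alone.

Measured compounds in a functional assay on HeLa cells (Homo sapiens) for inhibition, read by cell counting, with a stated time of 4 days; a lower number here means a stronger inhibitor, a higher number a weaker inhibitor:
compound 1 `C=C(Br)C(=O)Nc1cccc(-c2cn3nc(-c4ccc(OC)c(OC)c4)sc3n2)c1`: 610 nM
compound 3 `CCc1ccc(-c2nn3cc(-c4cccc(N)c4)nc3s2)cc1`: 8100 nM
compound 2 `Nc1cccc(-c2cn3nc(-c4ccc(F)cc4)sc3n2)c1`: the limit >= 250000 nM, not a number

Compound 2 stands at the limit of this assay, (the limit of >= 250000 nM in this assay, at which 1 of the 3 values shown sits). Compound 4 `Nc1cccc(-c2cn3nc(Cc4ccccc4)sc3n2)c1` differs from compound 2 by benzyl in place of 4-fluorophenyl on an aromatic carbon. Within the data shown here, the one measured step leaving compound 2 is an at least 30-fold lower number from compound 2 to compound 3 (1.48 log units; beyond the scatter), a different change on the same aromatic carbon; no measured step covers benzyl in place of 4-fluorophenyl. That step shows a change at this carbon can move the number far, so a large step is possible, but the direction from a limit can only be downward or none. Compound 4 is expected at 120000 nM, range 15000 nM to 250000 nM. The expected step is an at least 2.0-fold lower number from compound 2 to compound 4 (0.31 log units; beyond the scatter).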

Compound 4, half-maximal inhibitory concentration: 24000 nM
The estimate for compound 4 lay 5.0-fold (0.70 log units) above the measured number; low and high end bracket the measured number.
By their numbers in this assay, from the lowest: compound 1; then compound 3; then compound 4. At a limit, above all of these: compound 2.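

In this assay, benzyl in place of 4-fluorophenyl on this aromatic carbon gives an at least 10-fold lower number from compound 2 to compound 4 (1.01 log units; beyond the scatter). The aromatic ring therefore need not be attached directly to the core for a measurable value to be reached, and the earlier step showed this only for a directly attached ring. Compound 2 is a limit, not a number, so the step gives only a minimum size: the limit of >= 250000 nM in this assay, at which 1 of the 4 values shown sits.

Open, from the compounds shown here alone, is how an unsubstituted phenyl, a longer 2-phenylethyl chain or a morpholine would read on this carbon. Also open, going by these compounds, is whether a benzyl group and the bromo-substituted amide of compound 1 can be combined to any gain.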